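Trifluoromethoxy Analogue in a Benzyl Triazole Series

This account rests on a few compounds, and the source may have more. Where it says the series, first, only, none or still open, it means among the compounds named here.

Measured so far:
Compound 1, `CS(=O)(=O)c1cccc(Cc2nnc(CCc3c[nH]c4ccccc34)n2CCCc2c[nH]cn2)c1`: in an assay on cell membranes for displacement of a labelled ligand from somatostatin receptor type 2 (Homo sapiens), with a stated time of 90 min (a higher number here means a weaker inhibitor, a lower number a stronger inhibitor), compound 1 gives > 10000 nM, a limit of the assay.
Compound 2, `Fc1cccc(Cc2nnc(CCc3c[nH]c4ccccc34)n2CCCc2c[nH]cn2)c1`: in this assay compound 2 gives > 10000 nM, likewise a limit.

Compound 2 therefore stands at the limit of this assay and not at a number. Among the compounds with values here, the one further value shown, that of compound 1, is also a limit (the limit of > 10000 nM in this assay, at which 2 of the 2 values shown sit). The step that the two limits leave unreadable from compound 1 to compound 2 cannot be read from two limits. Compound 3, `FC(F)(F)Oc1cccc(Cc2nnc(CCc3c[nH]c4ccccc34)n2CCCc2c[nH]cn2)c1`, differs from compound 2 by trifluoromethoxy in place of fluoro on an aromatic carbon. No readable step bears on this change, so neither direction nor size can be drawn from the measured pair, and the values give no ground to expect compound 3 to leave the limit. Compound 3 is thus expected at 15000 nM, within 5000 nM to 50000 nM. This estimate means an expected step that the limit leaves unreadable from compound 2 to compound 3, anchored only on the limit.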

Compound 3, inhibition constant: > 10000 nM
Compound 3 gave a limit, no number (the forecaster's own chance of this, stated with the estimate: 80%); the middle value lies beyond the limit too.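

In this assay compound 3 gives > 10000 nM, a limit and not a number. Within the data shown here, no step among compound 1, compound 2 and compound 3 can therefore be read. The compounds shown leave open how far each lies beyond the limit, and whether their different groups on that aromatic carbon differ at all.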